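The compounds below may be only part of what the source reports. "The series", "measured", "known", "first", "only" and "open" are said of these compounds alone.

Series read in a functional assay on ECa-109 cells for antiproliferative activity against ECa-109 cell line (Homo sapiens), read by MTT assay, with a stated time of 48 h (on this read-out higher numbers stand for weaker inhibition and lower numbers for stronger inhibition), so far:
compound 1 `Clc1ccc(Cn2cc(CSc3nnc(-c4ccccc4)c(-c4ccccc4)n3)nn2)cc1` gives 24200 nM.
compound 2 `Brc1ccc(Cn2cc(CSc3nnc(-c4ccccc4)c(-c4ccccc4)n3)nn2)cc1` gives only a limit, > 100000 nM.
compound 3 `Cc1ccc(Cn2cc(CSc3nnc(-c4ccccc4)c(-c4ccccc4)n3)nn2)cc1` gives 12400 nM.

Among the two numbers compound 3 has the lower one, though a 2.0-fold lower number from compound 1 to compound 3 (0.29 log units; within the scatter) keeps it within the scatter of compound 1. Compound 4 `Fc1ccc(Cn2cc(CSc3nnc(-c4ccccc4)c(-c4ccccc4)n3)nn2)cc1` carries the change (fluoro in place of methyl on an aromatic carbon). Within the data shown here, the steps that bear on it are the swaps on the same aromatic carbon: a 2.0-fold lower number from compound 1 to compound 3 (0.29 log units; within the scatter), an at least 4.1-fold higher number from compound 1 to compound 2 (0.61 log units; beyond the scatter) and an at least 8.0-fold lower number from compound 2 to compound 3 (0.90 log units; beyond the scatter), the bromo cases sitting at the limit (the limit of > 100000 nM in this assay, at which 1 of the 3 values shown sits). Chloro to methyl moved little, so for fluoro in place of methyl a step of a 1.6-fold higher number from compound 3 to compound 4 (0.21 log units; within the scatter) in this assay is expected, likely within the scatter. Compound 4 is estimated at 20000 nM, between 8000 nM and 60000 nM.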

Compound 4, half-maximal inhibitory concentration: 19100 nM
Compound 4: middle estimate off by 1.0-fold (0.02 log units), on the high side; the range from low to high includes it.
By their numbers in this assay, from the lowest: compounds 3, 4 and 1 (each within the scatter of the next). At a limit, above all of these: compound 2.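

In this assay, fluoro on this aromatic carbon, para to a large group, cannot be told apart from methyl or chloro: a 1.5-fold higher number from compound 3 to compound 4 (0.19 log units; within the scatter) and a 1.3-fold lower number from compound 1 to compound 4 (0.10 log units; within the scatter). Compound 2 gives only a limit, not a number: the limit of > 100000 nM in this assay, at which 1 of the 4 values shown sits. Bromo alone goes against this flat picture, with an at least 5.2-fold lower number from compound 2 to compound 4 (0.71 log units; beyond the scatter) the only new step beyond the scatter.

From the compounds shown here alone, whether the bromo result is particular to bromo remains open. So does the outcome at this position with an amine, a carboxylic acid or a longer chain such as butyl.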